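Methyl on the Indole Nitrogen: Two Cores Compared

A few compounds are considered here, and "the series" means these few. Any claim that something is new, unique, unknown or untested is made for them only; others in the source may bear on it.

The measured compounds and their values:
Compound 1 `COc1cc2c(/C=C3/C(=O)Nc4ccc(Br)cc43)c(Cl)[nH]c2cc1C`: 14100 nM
Compound 2 `COc1cc2c(/C=C3/C(=O)Nc4cc(Cl)ccc43)c(Cl)[nH]c2cc1C`: 11500 nM
Compound 3 `COc1cc2c(/C=C3/C(=O)Nc4ccc(Br)cc43)c(Cl)n(C)c2cc1C`: 9330 nM

In a functional assay on NSCLC cells (Homo sapiens) for inhibition, with a stated time of 48 h (on this read-out higher numbers stand for weaker inhibition of growth and lower numbers for stronger inhibition of growth), compound 1 gives 14100 nM and compound 3 gives 9330 nM. The change from compound 1 to compound 3 is methyl in place of hydrogen on an aromatic nitrogen. It made a step of a 1.5-fold lower number from compound 1 to compound 3 (0.18 log units; within the scatter). Compound 2 gives 11500 nM in this assay; the difference between the core of compound 2 and the core of compound 1 is not broken down here. The values of compound 2 and compound 1 lie within the scatter of each other, as do those of compound 2 and compound 3.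

Compound 4 `COc1cc2c(/C=C3/C(=O)Nc4cc(Cl)ccc43)c(Cl)n(C)c2cc1C` has not yet been measured. It differs from compound 2 by methyl in place of hydrogen on an aromatic nitrogen. Going by the values given here, this is the same change as the one from compound 1 to compound 3, at the same place. He expects the step from compound 2 to compound 4 in this assay to be about a 1.4-fold lower number from compound 2 to compound 4 (0.13 log units; within the scatter), resting on the one earlier example, because the step of a 1.5-fold lower number from compound 1 to compound 3 (0.18 log units; within the scatter) stayed within the scatter. He estimates compound 4 at 8500 nM, between 3500 nM and 20000 nM.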

Compound 4, concentration for total growth inhibition: 11500 nM
Estimate against measurement, compound 4: 1.4-fold (0.13 log units) below; low and high end bracket the measured number.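

In this assay, methyl in place of hydrogen on the aromatic nitrogen of the five-membered ring gave no change at the digits printed from compound 2 to compound 4 (within the scatter). Set beside the earlier case, the two steps do not differ beyond what repeated measurements would scatter: the same change on two cores in this assay, a 1.5-fold lower number (0.18 log units; within the scatter) from compound 1 to compound 3 and no change at the digits printed (within the scatter) from compound 2 to compound 4, 1.5-fold (0.18 log units) apart, within the scatter of two such steps

Going by these compounds alone, the change can thus be carried from the core of compound 1 to the core of compound 2 with the same outcome, a step too small to be told from scatter on either core, but this agreement is only one between two small steps. It does not show that the methyl has any real effect on growth inhibition on either core, and two cores in one assay say nothing about a third core or another read-out.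

The compounds shown leave open whether a longer chain on that nitrogen, such as ethyl or propyl, or a chain ending in an amine or a carboxylic acid, would move the number beyond the scatter. They also leave open what a nitrile in place of the chloro group on the five-membered ring would do.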